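A few compounds are considered here, and "the series" means these few. Any claim that something is new, unique, unknown or untested is made for them only; others in the source may bear on it.

Compound 1 `O=c1cc(-c2ccccc2)oc2ccc(OCCCCCCN3CCC(O)CC3)cc12`: in an assay on isolated protein (Cavia porcellus) with Sigma non-opioid intracellular receptor 1 (Homo sapiens) as the target, read by radioligand binding (on this read-out higher numbers stand for weaker inhibition and lower numbers for stronger inhibition), compound 1 gives 100 nM. Compound 2 `CCN(CC)CCCCCCOc1ccc2oc(-c3ccccc3)cc(=O)c2c1`: compound 2 gives 91 nM. Compound 3 `O=c1cc(-c2ccccc2)oc2ccc(OCCCCCCN3CCNC(CCO)C3)cc12`: compound 3 gives 63 nM.

Compound 1 stands highest of the three numbers, though its neighbours sit close: the step of a 1.1-fold lower number from compound 1 to compound 2 (0.04 log units; within the scatter) and the step of a 1.6-fold lower number from compound 1 to compound 3 (0.20 log units; within the scatter) both fall within the scatter, so the three are not ordered. Compound 4 `COc1ccc(-c2cc(=O)c3cc(OCCCCCCN4CCC(O)CC4)ccc3o2)cc1` differs from compound 1 by methoxy in place of hydrogen on an aromatic carbon. Among the measured compounds shown here, every measured step, including a 1.4-fold lower number from compound 2 to compound 3 (0.16 log units; within the scatter), changes the amine at the chain end; none alters this ring, so no measured step bears on the change. The author therefore expects no step beyond the scatter, a 1.1-fold lower number from compound 1 to compound 4 (0.02 log units; within the scatter). Compound 4 is estimated at 95 nM, within 35 nM to 260 nM.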

Compound 4, half-maximal inhibitory concentration: 254 nM
The estimate for compound 4 lay 2.7-fold (0.43 log units) below the measured number; the measured number falls inside the stated range.
By their numbers in this assay, from the lowest: compounds 3, 2 and 1 (each within the scatter of the next); then compound 4.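

Going from phenyl to 4-methoxyphenyl gives a 2.5-fold higher number from compound 1 to compound 4 (0.40 log units; beyond the scatter) in this assay, a step beyond the scatter, whereas the amine changes among compounds 1, 2 and 3 all stayed within it. This aromatic carbon, para to a large group, is thus the first place shown where a change moves the number beyond the scatter. The data give no explanation for this step.

On these data alone, whether a fluorine or a hydroxyl on this carbon would move the number the same way stays open. So does whether methoxy gives a similar step with diethylamino at the chain end.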